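Diarylamine series: pyrrolidin-1-yl addition on the aniline ring

The compounds below may be only part of what the source reports. "The series", "measured", "known", "first", "only" and "open" are said of these compounds alone.

Measured so far:
compound 1 `c1ccc(NCc2ccc(CNc3ccccc3)cc2)cc1`: 54%
compound 2 `c1ccc(NCc2ccc(CNc3ncccn3)cc2)cc1`: 55%

Both numbers come from a functional assay on MDA-MB-231 cells for antagonist activity at C-X-C chemokine receptor type 4 (Homo sapiens), tested at 10 nM; a lower number here means a weaker effect, a higher number a stronger effect of the compound at the concentration tested. Compound 2 stands highest of the two numbers shown, with compound 1 nearest; the step of a number 1 percentage points higher from compound 1 to compound 2 (within the scatter) lies within the scatter, so the two compounds are not separated and no order between them is claimed.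

Compound 3 `c1cnc(NCc2ccc(CNc3ccccc3N3CCCC3)cc2)nc1` has not been measured. It differs from compound 2 by pyrrolidin-1-yl in place of hydrogen on an aromatic carbon. Of the measured steps, only a number 1 percentage points higher from compound 1 to compound 2 (within the scatter) exists, and it concerns the exchange of a group on an amine nitrogen, not a substituent on an aromatic carbon of a six-membered aromatic ring of carbon only. For the measured compounds named here, no measured step therefore bears on this change, and the two compounds so far give no direction for it. Without a guide, the number for compound 3 is expected to stay near that of compound 2, and the expected step is small, no change at the digits printed from compound 2 to compound 3 (within the scatter). For compound 3 the estimate in this assay is 55%, with a range from 35% to 75%.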

Compound 3, a percentage reported as inhibition, at one concentration (the size of the read-out at that concentration, not a potency): 61%
For compound 3 the middle estimate is 6 percentage points below the measured one, within the range that was stated.
By their numbers in this assay, from the lowest: compounds 1, 2 and 3 (each within the scatter of the next).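

In this assay, the series now has its first step on an aromatic carbon rather than on an amine nitrogen: pyrrolidin-1-yl in place of hydrogen gives a number 6 percentage points higher from compound 2 to compound 3 (within the scatter). This shows that a group of this size, with 5 heavy atoms in one five-membered non-aromatic ring, can stand on this aromatic carbon, ortho to a large group, without separating compound 3 from compound 2 in this read-out. No measurement is available that would explain this result or link it to any property of the group.

The finding rests on a single group at a single place and on a read-out at one concentration, so it gives no potency and does not show whether the step would differ with a dimethylamino group, a methoxy group or a carboxylic acid on the same aromatic carbon. On these data alone, it also remains open whether pyrrolidin-1-yl would behave in the same way on the aniline ring of compound 1, where the pyrimidin-2-yl group of compound 2 is replaced by phenyl.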